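Aryl Fluoride to Aryl Thiol: Buffer Stability Outlook

The source may hold more compounds than are shown below. What is called first, only, known or untested is meant among the compounds shown, and "the series" means these compounds.

Compound 2 `Fc1cc(C(F)(F)F)cc(C(F)(F)F)c1` carries a fluoro group on the shared core. In an ADME assay for pharmacokinetics, read by LC-MS, in phosphate buffer, with a stated time of 72 h, at pH 7.4, tested at 250 uM (a lower number here means that the compound disappears faster, a higher number that the compound lasts longer), compound 2 gives > 50 h, which is a limit of the assay rather than a number (the limit of > 50 h in this assay, at which 1 of the 2 values shown sits). For the measured compounds named here, its only measured neighbour is compound 1 `C=CC(=O)Oc1cc(C(F)(F)F)cc(C(F)(F)F)c1`, the acrylate ester. In this assay compound 1 gives < 0.017 h, likewise a limit (the limit of < 0.017 h in this assay, at which 1 of the 2 values shown sits). The step of an at least 2900-fold higher number from compound 1 to compound 2 (3.46 log units; beyond the scatter) is itself framed by those two limits.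

Compound 3 `FC(F)(F)c1cc(S)cc(C(F)(F)F)c1` is the next compound: sulfanyl in place of fluoro on an aromatic carbon. Going by the values given here, no measured step replaces fluoro by sulfanyl, and the single measured step, fluoro in place of (vinylcarbonyl)oxy, concerns a different group, so it bears on this change only by showing how far compound 2 sits from the short-lived end of the scale. The expected step of an at least 1.6-fold lower number from compound 2 to compound 3 (0.22 log units; that floor lies within the scatter) is estimated as a decrease of uncertain size, and it may yet fall within the scatter. Compound 3 is therefore expected to give 30 h in this assay, with a range from 5 h to 100 h.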

Compound 3, half-life: > 50 h
Compound 3 ended at the assay's limit; the forecaster's own chance of this, stated with the estimate: 40%; middle value at least 1.6-fold (0.22 log units) from the limit.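

In this assay compound 3 gives > 50 h, which is a limit of the assay and not a number. Long persistence at this position is therefore not confined to fluoro: sulfanyl, on the same aromatic carbon meta to two trifluoromethyl groups, also reaches the long-lasting end of the scale, and replacing the acrylate ester with sulfanyl gives an at least 2900-fold higher number from compound 1 to compound 3 (3.46 log units; beyond the scatter). The step between the fluoro and sulfanyl compounds cannot be read, and no order between them follows from values that share one limit: the limit of > 50 h in this assay, at which 2 of the 3 values shown sit.

The compounds shown leave open how long compound 2 and compound 3 actually last beyond that limit, and so whether the change from fluoro to sulfanyl has any effect in this assay. They also leave open whether an amine or a carboxylic acid on this aromatic carbon would stay at the long-lasting limit or move toward the short-lived end, where compound 1 stands.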